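From compound 1 to compound 4: replacing the acetyl

The source may report more compounds than this note shows. Statements on the series, on what has been measured and on what is new or still open speak of the compounds shown alone.

Measured in an ADME assay on MT4 cells (Homo sapiens) for cytotoxicity, read by MTT assay, with a stated time of 96 h; on this read-out higher numbers stand for lower toxicity in this test and lower numbers for higher toxicity in this test:
compound 1 `CC(=O)c1ccc2[nH]c(-c3ccc(Cl)cc3)nc2c1` gives "not determined" (no result reported)
compound 2 `CC(=O)c1ccc2[nH]c(-c3ccc(C(F)(F)F)cc3)nc2c1` gives "not determined" (no result reported)
compound 3 `COc1ccc(-c2nc3cc(C(C)=O)ccc3[nH]2)c(OC)c1OC` gives > 100000 nM (a limit)

Compound 1 has no number in this assay to serve as a starting point, and neither has compound 2. Within the data shown here, the only reading in this small set, that of compound 3, is a limit (the limit of > 100000 nM in this assay, at which 1 of the 3 values shown sits).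

The unmeasured compound 4 `C/C(=N\O)c1ccc2[nH]c(-c3ccc(Cl)cc3)nc2c1` shares the core of compound 1. The change is a group of 4 heavy atoms (2 carbon, 1 nitrogen, 1 oxygen; no ring) in place of a group of 3 heavy atoms (2 carbon, 1 oxygen; no ring), on an aromatic carbon, and it sits on an aromatic carbon of the six-membered aromatic ring of carbon only. Among the measured compounds shown here, no measured step bears on this change, so no step beyond the scatter is expected in this assay, and no direction is predicted. The expectation of low toxicity rests only on compound 3, whose > 100000 nM is a limit. For compound 4 the estimated half-maximal cytotoxic concentration is 50000 nM, with an expected range from 12000 nM to 100000 nM.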

Compound 4, half-maximal cytotoxic concentration: 20000 nM
Beside the measured number, compound 4's estimate is 2.5-fold (0.40 log units) above it; the measured number falls inside the stated range.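

In this assay compound 4 gives 20000 nM, but compound 1 has no number there, and no step can be read between them. Whether replacing the acetyl shifts toxicity in this test stays open, and the only other reading is a limit: the limit of > 100000 nM in this assay, at which 1 of the 4 values shown sits.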